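Second hydroxy on the core of compound 3

This account rests on a few compounds, and the source may have more. Where it says the series, first, only, none or still open, it means among the compounds named here.

In an ADME assay on L6 cells (Rattus norvegicus) for inhibition, read by fluorescence, with a stated time of 72 h (on this read-out higher numbers stand for weaker inhibition and lower numbers for stronger inhibition), compound 1 `CCc1cc(=O)oc2cc(Oc3ccc(Cl)cc3O)ccc12` gives 84800 nM, compound 2 `O=c1oc2ccccc2cc1Oc1ccc(Cl)cc1O` gives 108000 nM and compound 3 `O=c1oc2cc(O)ccc2cc1Oc1ccc(Cl)cc1O` gives 144000 nM. These three values lie within the scatter of one another, so compound 3 stands level with both neighbours. Compound 4 `O=c1oc2cc(O)cc(O)c2cc1Oc1ccc(Cl)cc1O` differs from compound 3 by hydroxy in place of hydrogen on an aromatic carbon, a hydroxy in place of hydrogen on an aromatic carbon, meta to a hydroxy group. One measured step is of the same kind: a 1.3-fold higher number from compound 2 to compound 3 (0.12 log units; within the scatter), which stays within the scatter. A single step is thin support, but no shift beyond the scatter is expected in this assay. The expected change is a 1.0-fold lower number from compound 3 to compound 4 (0.01 log units; within the scatter). Compound 4 is estimated at 140000 nM, with an expected range from 65000 nM to 280000 nM.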

Compound 4, half-maximal inhibitory concentration: 128000 nM
Beside the measured number, compound 4's estimate is 1.1-fold (0.04 log units) above it, within the range that was stated.
By their numbers in this assay, from the lowest: compounds 1, 2, 4 and 3 (each within the scatter of the next).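

The added hydroxy, meta to a hydroxy group, gives a 1.1-fold lower number from compound 3 to compound 4 (0.05 log units; within the scatter). Together with a 1.3-fold higher number from compound 2 to compound 3 (0.12 log units; within the scatter), this shows that a second hydroxy in place of hydrogen on an aromatic carbon of the shared core, like the first, leaves the number in this assay within the scatter across compounds 2, 3 and 4. No evidence in hand bears on why the number stays level at this position.

Going by these compounds, whether an amine or a carboxylic acid on this aromatic carbon would move the number beyond the scatter remains open. So does the effect of a methoxy in place of this hydroxy.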